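Swapping the aniline ring on a shared quinazoline-like core

The compounds below may be only part of what the source reports. "The series", "measured", "known", "first", "only" and "open" are said of these compounds alone.

Measured so far in a functional assay on A549 cells (Homo sapiens) for antiproliferative activity, read by MTT assay, with a stated time of 72 h; on this read-out higher numbers stand for weaker inhibition and lower numbers for stronger inhibition:
- compound 1 `COc1cc2ncnc(Nc3ccc(F)c(Cl)c3)c2cc1OCCCCC(=O)Nc1ccc(S(N)(=O)=O)cc1`: 15500 nM
- compound 2 `COc1ccc(Nc2ncnc3cc(OC)c(OCCCCC(=O)Nc4ccc(S(N)(=O)=O)cc4)cc23)cc1OC`: a limit, > 40000 nM
- compound 3 `COc1cc2ncnc(Nc3cccc(Cl)c3F)c2cc1OCCCCC(=O)Nc1ccc(S(N)(=O)=O)cc1`: 10500 nM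

Compound 3 gives the lowest of the two numbers, yet the gap between them is a 1.5-fold lower number from compound 1 to compound 3 (0.17 log units; within the scatter), so the two cannot be told apart. Compound 2 shows only a limit of this assay, which is noted in the limit of > 40000 nM in this assay, at which 1 of the 3 values shown sits, and the move from compound 2 to compound 3 is an at least 3.8-fold lower number from compound 2 to compound 3 (0.58 log units; beyond the scatter).

Compound 4 `COc1cc2ncnc(Nc3cc(F)c(F)c(F)c3)c2cc1OCCCCC(=O)Nc1ccc(S(N)(=O)=O)cc1` has not yet been measured. It differs from compound 3 in one place: 3,4,5-trifluorophenyl in place of 3-chloro-2-fluorophenyl on a nitrogen on an aromatic ring. The three measured compounds share everything except this ring on the nitrogen, so all steps bear on the change. Exchanging one halogenated ring for another gave a 1.5-fold lower number from compound 1 to compound 3 (0.17 log units; within the scatter), whereas moving to the dimethoxy ring gave an at least 2.5-fold higher number from compound 1 to compound 2 (0.41 log units; beyond the scatter). Compound 4 keeps a halogenated ring, so the step is expected to stay within or near the scatter, with the estimate leaning toward a somewhat higher number, a 1.4-fold higher number from compound 3 to compound 4 (0.15 log units; within the scatter). The expected value for compound 4 in this assay is 15000 nM, within a range from 6000 nM to 38000 nM.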

Compound 4, half-maximal inhibitory concentration: > 40000 nM
Compound 4 gave a limit, no number (the forecaster's own chance of this, stated with the estimate: 15%); middle value at least 2.6-fold (0.42 log units) from the limit.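

Until now, only the 3,4-dimethoxyphenyl ring had pushed a compound out of the measurable range in this assay, while both halogenated rings had kept a number, and compound 4 shows that carrying halogens is not enough to keep one. Placing 3,4,5-trifluorophenyl on the nitrogen in place of 3-chloro-2-fluorophenyl gives an at least 3.8-fold higher number from compound 3 to compound 4 (0.58 log units; beyond the scatter), and in place of 3-chloro-4-fluorophenyl it gives an at least 2.5-fold higher number from compound 1 to compound 4 (0.41 log units; beyond the scatter), so among these compounds the choice of halogens on this ring matters, not merely their presence. Compound 4 stands at a limit and not at a number, as compound 2 does, so the step between those two cannot be read: the limit of > 40000 nM in this assay, at which 2 of the 4 values shown sit.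

The step to compound 4 removes the chlorine and changes the fluorines in a single move, so the compounds shown cannot tell which part of the change goes with the loss of activity, and a 3-chlorophenyl or a 3,4-difluorophenyl ring on the nitrogen would help to separate them. On these data alone, all four compounds also share one chain on the core, so it remains open whether these differences would hold with a shorter chain or with a carboxylic acid at its end.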